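This account rests on a few compounds, and the source may have more. Where it says the series, first, only, none or still open, it means among the compounds named here.

Measured in a functional assay, read by spectrophotometry, with a stated time of 2 h; on this read-out lower numbers stand for stronger inhibition and higher numbers for weaker inhibition:

- compound 1 `CCOC(=O)C1=C(C)NC(=O)NC1c1cccc([N+](=O)[O-])c1`: 27.7 ug/mL
- compound 2 `COC(=O)C1=C(C)NC(=O)NC1c1ccc(OC)cc1`: 31.7 ug/mL

Only these two numbers are available so far. In this assay compound 2 gives 31.7 ug/mL, and compound 1 gives 27.7 ug/mL. The two lie within the usual scatter of repeated measurements, so neither can be called the stronger inhibitor.

The next compound is compound 3 `COC(=O)C1=C(C)NC(=O)NC1c1ccc(O)cc1`. Its structure departs from compound 2 in one place: hydrogen in place of methyl on an oxygen on an aromatic ring. This is hydrogen in place of methyl on an oxygen on an aromatic ring, or methoxy to hydroxy.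

Within the data shown here, no measured pair here shows what this change does on its own, so any forecast is weakly grounded. Compound 1 differs from compound 2 in more than one place, yet compound 1 at 27.7 ug/mL stays within the scatter of compound 2 at 31.7 ug/mL. On that basis, no shift beyond the scatter is expected in this assay. The expected change is small, namely a 1.2-fold lower number from compound 2 to compound 3 (0.09 log units; within the scatter). For compound 3 the estimated value is 26 ug/mL, with an expected range from 12 ug/mL to 55 ug/mL.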

Compound 3, half-maximal inhibitory concentration: 3.14 ug/mL
The estimate for compound 3 lay 8.3-fold (0.92 log units) above the measured number; measured number below the stated range.
By their numbers in this assay, from the lowest: compound 3; then compounds 1 and 2 (each within the scatter of the next).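

In this assay, among these compounds, the swap of methyl for hydrogen on the oxygen on the aromatic ring, methoxy to hydroxy, gives a 10-fold lower number from compound 2 to compound 3 (1.00 log units; beyond the scatter) and so provides the first measured pair here that differs in one place only. It shows that this position is not indifferent to change: with the rest of the structure the same, the loss of one methyl group is enough to give a clearly stronger inhibitor in this read-out. Nothing available here explains why the hydroxy compound gives the lower number, so the step stands as an observation without a stated cause.

This single step cannot say whether the hydroxy group itself matters or whether other small groups on the aromatic ring would do equally well. From the compounds shown here alone, an amine or a carboxylic acid in place of the hydroxy, or a longer chain such as ethoxy in place of the methoxy, would be needed to show how much of the step belongs to that group, and whether the same change gives a similar step on other versions of the shared core remains open too.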